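Swapping fluoro for chloro on the fused core

The compounds below may be only part of what the source reports. "The series", "measured", "known", "first", "only" and "open" are said of these compounds alone.

Measured so far:
compound 1, `O=S(=O)(c1ccc(F)cc1)c1cnc2cc(F)c(Cl)cc2c1-c1ccc(Cl)cc1` — 43.7%
compound 2, `O=S(=O)(c1ccc(F)cc1)c1cnc2cc(Cl)c(F)cc2c1-c1ccc(Cl)cc1` — 48%
compound 3, `O=S(=O)(c1ccc(F)cc1)c1cnc2ccc(F)cc2c1-c1ccc(Cl)cc1` — 76.3%

In an assay on cell membranes for displacement of a labelled ligand from metabotropic glutamate receptor 5 (Rattus norvegicus), with a stated time of 60 min, tested at 1 uM (a higher number here means more inhibition at the concentration tested (going by the name of the read-out), a lower number less inhibition), compound 3 gives 76.3%, the highest of the three numbers; compound 2 gives 48% and compound 1 gives 43.7%, both beyond the scatter below it. Compound 4, `O=S(=O)(c1ccc(F)cc1)c1cnc2ccc(Cl)cc2c1-c1ccc(Cl)cc1`, differs from compound 3 by one substituent: chloro in place of fluoro on an aromatic carbon. Among the measured compounds shown here, only one measured step changes a single position on that core, a number 28.3 percentage points higher from compound 2 to compound 3 (beyond the scatter), where removing a chloro raised the read-out. Compound 1 and compound 2 both carry a chloro together with a fluoro on the fused ring and both sit well below compound 3, though neither pair with compound 3 is a one-place change, so nothing is known about fluoro against chloro at the same place. Putting a chloro onto the core where compound 3 has fluoro is therefore expected to lower the read-out for compound 4, a step of a number 18.3 percentage points lower from compound 3 to compound 4 (beyond the scatter) beyond the scatter. That expected drop is smaller in size than the measured step of a number 28.3 percentage points higher from compound 2 to compound 3 (beyond the scatter). The estimate for compound 4 is 58%, with a range from 38% to 78%.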

Compound 4, a percentage reported as inhibition, at one concentration (the size of the read-out at that concentration, not a potency): 58.3%
Compound 4: the middle estimate sits 0.3 percentage points below what was measured, within the range that was stated.
By their numbers in this assay, from the lowest: compounds 1 and 2 (each within the scatter of the next); then compound 4; then compound 3.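

In this assay this place on the shared core now has a direct comparison of the two halogens, and the step is a number 18 percentage points lower from compound 3 to compound 4 (beyond the scatter) with chloro in place of fluoro on the same aromatic carbon, so fluoro and chloro do not give the same read-out here. With that chloro held fixed, hydrogen in place of fluoro on another aromatic carbon of the ring gives a number 14.6 percentage points higher from compound 1 to compound 4 (beyond the scatter) and so shows that taking off a fluoro can raise the read-out, just as taking off a chloro did in the earlier step, a number 28.3 percentage points higher from compound 2 to compound 3 (beyond the scatter) in that case. Both removals point the same way and no compound shown goes against them, though this rests on only these two pairs.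

As far as these compounds go, it remains open how a methoxy group, an amine or a nitrile at this place would compare with fluoro and chloro. From the compounds shown here alone, it also remains open whether the swap of fluoro for chloro would go the same way with a different group on the sulfonyl side of the core. Nothing at hand explains why either change moves the read-out.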